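Changing the sulfur-linked side chain: an estimate for compound 4

The compounds below may be only part of what the source reports. "The series", "measured", "known", "first", "only" and "open" are said of these compounds alone.

Measured so far:
compound 1, `Cc1cc(N2CC[C@@H](C)[C@@H](N(C)c3ncnc4[nH]ccc34)C2)n2nc(SCC3CCCCC3)nc2n1`: 11500 nM
compound 2, `Cc1cc(N2CC[C@@H](C)[C@@H](N(C)c3ncnc4[nH]ccc34)C2)n2nc(SCc3cc(Cl)ccc3Cl)nc2n1`: 19200 nM
compound 3, `Cc1cc(N2CC[C@@H](C)[C@@H](N(C)c3ncnc4[nH]ccc34)C2)n2nc(SCc3ccc([N+](=O)[O-])cc3)nc2n1`: 29400 nM

In a functional assay on HGC-27 cells (Homo sapiens) for inhibition, read by MTT assay, with a stated time of 72 h (a higher number here means a weaker inhibitor, a lower number a stronger inhibitor), compound 2 stands second highest of the three numbers, and both its neighbours lie within the scatter of it: a 1.7-fold higher number from compound 1 to compound 2 (0.22 log units; within the scatter) and a 1.5-fold higher number from compound 2 to compound 3 (0.19 log units; within the scatter). Among the measured compounds shown here, only the step of a 2.6-fold higher number from compound 1 to compound 3 (0.41 log units; beyond the scatter) reaches beyond the scatter, and that one is modest.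

Compound 4, `Cc1cc(N2CC[C@@H](C)[C@@H](N(C)c3ncnc4[nH]ccc34)C2)n2nc(SCCCc3ccccc3)nc2n1`, differs from compound 2 in one place: phenethyl in place of 2,5-dichlorophenyl on a saturated chain carbon bound to a sulfur. For the measured compounds named here, the steps that bear on this, from compound 1 to compound 2 and from compound 2 to compound 3, each swapped the group on the saturated chain carbon bound to a sulfur and each stayed within the scatter. The same is therefore expected here, with no step beyond the scatter in either direction: compound 4 is estimated at a 1.2-fold lower number from compound 2 to compound 4 (0.08 log units; within the scatter). Compound 4 is expected near 16000 nM, between 6500 nM and 40000 nM.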

Compound 4, half-maximal inhibitory concentration: > 100000 nM
Compound 4: no number, only a limit; the forecaster's own chance of this, stated with the estimate: 5%; at least 6.2-fold (0.79 log units) between middle value and limit.
By their numbers in this assay, from the lowest: compounds 1, 2 and 3 (each within the scatter of the next, the first and the last beyond it). At a limit, above all of these: compound 4.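

Compound 4 reads only as a limit, not a number: the limit of > 100000 nM in this assay, at which 1 of the 4 values shown sits. On a saturated chain carbon bound to a sulfur, the earlier swaps gave steps no larger than modest, whereas phenethyl gives steps beyond the scatter against all three compounds: an at least 5.2-fold higher number from compound 2 to compound 4 (0.71 log units; beyond the scatter), an at least 3.4-fold higher number from compound 3 to compound 4 (0.53 log units; beyond the scatter) and an at least 8.6-fold higher number from compound 1 to compound 4 (0.93 log units; beyond the scatter). Phenethyl and 2,5-dichlorophenyl have the same count of heavy atoms and one six-membered aromatic ring each, so these counts alone do not settle the result at this position.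

The compounds shown leave open whether unsubstituted benzyl or an amine on the 3-phenylpropyl chain would give a measurable number. On these data alone, how far compound 4 lies past its limit also stays open.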